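The compounds below may be only part of what the source reports. "The series", "measured", "known", "first", "only" and "open" are said of these compounds alone.

Measured so far:
compound 1 `Oc1cc(C(F)(F)F)ccc1-c1nc(-c2ccccc2O)n(-c2ccc(Br)cc2)n1` — 100%
compound 2 `Oc1cc(C(F)(F)F)ccc1-c1nc(-c2ccccc2O)n(-c2ccccc2F)n1` — 100%

In a functional assay on PC-12 cells (Rattus norvegicus) for cytotoxicity, read by MTT assay, with stated times of 2 h and 24 h, tested at 10 uM (on this read-out lower numbers stand for a weaker effect and higher numbers for a stronger effect at the one concentration tested), compound 1 gives 100%. Compound 2 gives 100%, with no change at the digits printed from compound 1 to compound 2 (within the scatter); compound 2 therefore stands level with compound 1 within the scatter.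

Compound 3 `Oc1cc(C(F)(F)F)ccc1-c1nc(-c2ccccc2O)n(-c2cccc(F)c2)n1` differs from compound 2 by 3-fluorophenyl in place of 2-fluorophenyl on an aromatic nitrogen. Within the data shown here, the one step that bears on this is no change at the digits printed from compound 1 to compound 2 (within the scatter), an exchange of the group on the same aromatic nitrogen, which left the read-out unchanged. The expected step is a number 2 percentage points lower from compound 2 to compound 3 (within the scatter), none beyond the scatter. Compound 3 is estimated at 98%, range 85% to 100%.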

Compound 3, a percentage reported as activity, at one concentration (the size of the read-out at that concentration, not a potency): 98.3%
Compound 3: the middle estimate sits 0.3 percentage points below what was measured; the measured number falls inside the stated range.
By their numbers in this assay, from the lowest: compounds 3, 1 and 2 (each within the scatter of the next).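

In this assay the exchange of 2-fluorophenyl for 3-fluorophenyl on the aromatic nitrogen gives a number 1.7 percentage points lower from compound 2 to compound 3 (within the scatter) and so shows no effect of where the fluorine sits on this phenyl group. The exchange of 4-bromophenyl for 3-fluorophenyl gives a number 1.7 percentage points lower from compound 1 to compound 3 (within the scatter) and leaves all three substituted phenyl groups at this nitrogen level. No measured data explain this flat result.

Going by these compounds, whether a phenyl group carrying an amine or a carboxylic acid would move the read-out at this nitrogen remains open. On these data alone, the effect of changes elsewhere on the shared core also remains open.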